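From Compound 2 to Compound 3: Expected Vero Cell Cytotoxicity

The compounds below may be only part of what the source reports. "The series", "measured", "known", "first", "only" and "open" are said of these compounds alone.

Of the compounds shown here, two sharing one core have been tested in an ADME assay on Vero cells (Chlorocebus sabaeus) for cytotoxicity, read by neutral red uptake, tested at 49 ug/mL; on this read-out lower numbers stand for a stronger effect and higher numbers for a weaker effect at the one concentration tested. Compound 1, `COc1ccc(C2SCC(=O)N2CCN2CCCCC2)cc1`, gives 100% in this assay. Compound 2, `O=C1CSC(c2ccc(O)cc2)N1CCN1CCCCC1`, gives 96%. Within the data shown here, the single measured step between them, hydrogen in place of methyl on an oxygen on an aromatic ring, is a number 4 percentage points lower from compound 1 to compound 2 (within the scatter), so compound 2 stands beside compound 1 rather than apart from it.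

Compound 3, `O=C1CSC(c2ccccc2Cl)N1CCN1CCCCC1`, has not yet been measured. It differs from compound 2 as follows: 2-chlorophenyl in place of 4-hydroxyphenyl on a saturated ring carbon. Among the measured compounds shown here, no measured step exchanges the aromatic ring itself, so the one recorded step bears on this change only in showing that the core tolerated a small edit without moving beyond the scatter. With both measured numbers sitting high, compound 3 is expected to remain near that level, with at most a modest move toward a stronger effect. Compound 3 is therefore expected to give 90%, within a range from 72% to 100%. The step this estimate implies for compound 3 is expected to be a number 6 percentage points lower from compound 2 to compound 3 (within the scatter), which may or may not exceed the scatter.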

Compound 3, a percentage reported as activity, at one concentration (the size of the read-out at that concentration, not a potency): 100%
Beside the measured number, compound 3's estimate is 10 percentage points below it; the measured number falls inside the stated range.
By their numbers in this assay, from the lowest: compounds 2, 1 and 3 (each within the scatter of the next).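

In this assay, exchanging the aromatic ring itself on the saturated ring carbon, with 2-chlorophenyl in place of 4-hydroxyphenyl, gives a number 4 percentage points higher from compound 2 to compound 3 (within the scatter) for this change. The earlier step touched only the methyl on an oxygen of the aromatic ring, whereas this one shows that the ring's substituent can be replaced outright at this position, next to the ring nitrogen and next to the ring sulfur, and that the hydrogen-bond donor and acceptor counted on 4-hydroxyphenyl are absent from 2-chlorophenyl while compound 2 and compound 3 remain within the scatter of each other. Nothing measured here accounts for how closely these two compounds read, so the result stands as an observation only.

The compounds shown leave open whether any group at this position can carry the read-out beyond the scatter, such as an amine or a carboxylic acid on the aromatic ring, or a longer chain in place of that ring. Also open, going by these compounds, is how the chlorine and its place on the ring count separately, since the substituent and its place on the ring differ together in this one step.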